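The source may hold more compounds than are shown below. What is called first, only, known or untested is meant among the compounds shown, and "the series" means these compounds.

Measured in a toxicity assay on cells (Macrophage, Mus musculus, strain BALB/c) for cytotoxicity, read by MTT assay (a lower number here means a stronger inhibitor, a higher number a weaker inhibitor), so far:
- compound 1 `COc1cc(O)cc(O)c1C(=O)/C=C/c1ccco1` with 384000 nM 
- compound 2 `C=CCOc1cc(OC)c(C(=O)/C=C/c2ccccc2F)c(OCC=C)c1` with 13300 nM 

Compound 1 holds the higher of these two numbers, and the gap down to compound 2 lies beyond the usual scatter. Compound 3 `COc1cc(O)cc(O)c1C(=O)/C=C/c1ccccc1Br` has not yet been measured. It keeps the core of compound 1 but carries 2-bromophenyl in place of furan-2-yl on a double-bonded chain carbon bound to a double-bonded chain carbon, as counted here: 2-bromophenyl in place of furan-2-yl on a double-bonded chain carbon bound to a double-bonded chain carbon. Among the compounds with values here, no measured pair isolates such a change, so the data offer only a rough guide. Compound 2 , at 13300 nM, shows that much lower numbers occur in this small set. A clear downward move is therefore expected, estimated as a 7.7-fold lower number from compound 1 to compound 3 (0.89 log units; beyond the scatter), and beyond the scatter. For compound 3 the expected value is 50000 nM, with an estimated range from 15000 nM to 150000 nM as its bounds.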

Compound 3, half-maximal inhibitory concentration: 14600 nM
Compound 3: middle estimate off by 3.4-fold (0.53 log units), on the high side, and the stated range ends above it.
By their numbers in this assay, from the lowest: compounds 2 and 3 (each within the scatter of the next); then compound 1.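

Placing 2-bromophenyl in place of furan-2-yl on a double-bonded chain carbon bound to a double-bonded chain carbon gives, in this assay, a 26-fold lower number from compound 1 to compound 3 (1.42 log units; beyond the scatter). Within the data shown here, this is the first pair in the set that differs in one place only, so the effect of a change at this chain carbon can now be read directly, with the core of compound 1 held fixed, and it is large. No evidence at hand gives a reason for this step.

From the compounds shown here alone, whether the step belongs to the bromine or to the carbon-only six-membered ring as such remains open, as does how a plain phenyl or a 2-chlorophenyl would read at this place on the same core. Also open, going by these compounds, is what an amine or a carboxylic acid on that ring would do to the number.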